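Dihalogenated and methoxylated aryl ketones on a shared pyrazole core

A few compounds are considered here, and "the series" means these few. Any claim that something is new, unique, unknown or untested is made for them only; others in the source may bear on it.

Measured compounds:
- compound 1 `COc1cc(-c2cc(/C=C/C(=O)c3ccc(Cl)c(Cl)c3)[nH]n2)cc(OC)c1OC`: 88%
- compound 2 `COc1ccc(C(=O)/C=C/c2cc(-c3cc(OC)c(OC)c(OC)c3)n[nH]2)cc1`: 87%

Both compounds share a core and differ only in the aryl group on the carbonyl carbon. In a functional assay on SF-539 cells (Homo sapiens) for cytotoxicity, read by sulforhodamine B assay, with a stated time of 48 h, tested at 1 uM (on this read-out higher numbers stand for a weaker effect at the one concentration tested and lower numbers for a stronger effect), compound 1 gives 88%, and compound 2 gives 87%. The one step between them, a number 1 percentage points lower from compound 1 to compound 2 (within the scatter), is within the scatter, so on the numbers shown compound 2 stands alongside compound 1 rather than apart from it; with only two values, it is simply the lower of the pair and the difference is not a meaningful one.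

Compound 3 `COc1cc(-c2cc(/C=C/C(=O)c3ccc(F)c(F)c3)[nH]n2)cc(OC)c1OC` is not yet measured. It differs from compound 2 as follows: 3,4-difluorophenyl in place of 4-methoxyphenyl on a carbonyl carbon. Within the data shown here, the only step that bears on this change is the one from compound 1 to compound 2, which swapped a dihalogenated phenyl for the 4-methoxyphenyl without moving the read-out beyond the scatter. Returning to a dihalogenated phenyl, now with fluorine, is therefore expected to leave the result essentially where it is, with a number 1 percentage points higher from compound 2 to compound 3 (within the scatter) expected to stay within the scatter. The estimate for compound 3 in this assay is 88%, expected to lie between 78% and 98%.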

Compound 3, a percentage reported as activity, at one concentration (the size of the read-out at that concentration, not a potency): 90%
The estimate for compound 3 lay 2 percentage points below the measured number; the range from low to high includes it.
By their numbers in this assay, from the lowest: compounds 2, 1 and 3 (each within the scatter of the next).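

In this assay, the exchange of the aryl group on the carbonyl carbon now covers a second halogen as well as the methoxy group: 3,4-difluorophenyl gives a number 3 percentage points higher from compound 2 to compound 3 (within the scatter) when it replaces 4-methoxyphenyl, and a number 2 percentage points higher from compound 1 to compound 3 (within the scatter) when it replaces 3,4-dichlorophenyl. The earlier pair compared only a chlorinated ring with a methoxylated one, whereas these steps show that swapping chlorine for fluorine on the same 3,4-disubstituted pattern also leaves the read-out within the scatter, so none of the three aryl groups stands apart at this position. Nothing available accounts for this flatness.

The compounds shown leave open whether any group at this position would separate from these three, for example a phenyl ring carrying an amine or a carboxylic acid, or a longer chain in place of the ring. They also leave open whether changes elsewhere on the shared core would move the read-out, and whether the three compounds would still stand together at other concentrations.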